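The compounds below may be only part of what the source reports. "The series", "measured", "known", "first", "only" and "open" are said of these compounds alone.

Compound 1, `C=CC1=C(C(=O)Nc2ccccc2)C(c2ccc(Cl)c(Cl)c2)OC1`, in a functional assay on SW480 cells (Homo sapiens) for cytotoxicity, read by MTT assay, with a stated time of 24 h; a lower number here means a stronger inhibitor, a higher number a weaker inhibitor: > 100000 nM, a limit of the assay.
Compound 2, `C=CC1=C(C(=O)NCc2ccccc2)C(c2ccc(Cl)c(Cl)c2)OC1`, in this assay: > 100000 nM, again only a limit.
Compound 3, `C=CC1=C(C(=O)Nc2ccccc2OC)C(c2ccc(Cl)c(Cl)c2)OC1`, in this assay: > 100000 nM, likewise only a limit.

Compound 3 therefore stands nowhere that can be ranked: its result in this assay is a limit, and it shares that standing with the two other measured compounds, as the limit of > 100000 nM in this assay, at which 3 of the 3 values shown sit, records. The steps among the measured compounds give no readable size, since a step that the two limits leave unreadable from compound 1 to compound 2, a step that the two limits leave unreadable from compound 1 to compound 3 and a step that the two limits leave unreadable from compound 2 to compound 3 all run between two limits.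

Compound 4, `C=CC1=C(C(=O)NCCCCC)C(c2ccc(Cl)c(Cl)c2)OC1`, has not yet been measured in this assay. It differs from compound 3 in one place: pentyl in place of 2-methoxyphenyl on an amide-type nitrogen. For the measured compounds named here, no measured step bears on this change in a readable way, so no direction can be read from the data, and the expectation rests only on the shared standing of compounds 1, 2 and 3 at the limit. The step from compound 3 to compound 4 is expected to be a step that the limit leaves unreadable from compound 3 to compound 4, which is to say no movement that can be told from the scatter. Compound 4 is estimated to give 150000 nM in this assay, within a range from 50000 nM to 600000 nM, and most likely the assay will again report only a limit.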

Compound 4, half-maximal inhibitory concentration: 27500 nM
The estimate for compound 4 lay 5.5-fold (0.74 log units) above the measured number; measured number below the stated range.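

On this amide-type nitrogen, the change of group now gives a readable result in this assay: pentyl in place of 2-methoxyphenyl gives an at least 3.6-fold lower number from compound 3 to compound 4 (0.56 log units; beyond the scatter). The two other changes point the same way, with pentyl in place of phenyl giving an at least 3.6-fold lower number from compound 1 to compound 4 (0.56 log units; beyond the scatter) and butyl in place of phenyl on the saturated chain carbon giving an at least 3.6-fold lower number from compound 2 to compound 4 (0.56 log units; beyond the scatter). Compound 4 alone has a measured number rather than a limit, and it alone has no ring in the group on this nitrogen, while the steps among the other three cannot be read and those compounds share one standing: the limit of > 100000 nM in this assay, at which 3 of the 4 values shown sit.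

With only one open chain shown, it remains open whether a shorter propyl or a longer octyl chain would lower the number further or raise it. Also open, as far as these compounds go, is whether a cyclohexyl group, a saturated ring, would behave like pentyl or like the ring-bearing groups, and whether a chain ending in an amine would keep the gain.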